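Swapping a benzyloxy arm for a chlorinated ring

This account rests on a few compounds, and the source may have more. Where it says the series, first, only, none or still open, it means among the compounds named here.

The three measured compounds share one core, and all of them are tolerated by the cells only at high concentrations. In a functional assay on HEL cells (Homo sapiens) (a lower number here means that less compound is tolerated, a higher number that more compound is tolerated), compound 1 `O=C1c2ccccc2N(Cc2ccccc2)S(=O)(=O)N1COCc1ccccc1` gives 49000 nM, the lowest of the two numbers shown. Compound 3 `C#CCOCN1c2ccccc2C(=O)N(Cc2ccccc2)S1(=O)=O` gives 140000 nM in this assay, a number sitting higher than that of compound 1 by more than the usual scatter. Compound 2 `O=C1c2ccccc2N(Cc2ccc(Cl)cc2)S(=O)(=O)N1Cc1ccc(Cl)cc1` gives only a limit in this assay, > 50000 nM, so no exact number is known for it; (the limit of > 50000 nM in this assay, at which 1 of the 3 values shown sits).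

The new compound 4 `O=C1c2ccccc2N(Cc2ccccc2)S(=O)(=O)N1Cc1ccccc1Cl` differs from compound 1 in one place: 2-chlorophenyl in place of benzyloxy on a saturated chain carbon bound to an amide-type nitrogen in a ring. Among the measured compounds shown here, no measured pair shows this exact change, so only the spread of the three compounds above can guide an expectation. All of them sit in the same high region, and the change keeps the size of the group on that carbon nearly unchanged. The step from compound 1 to compound 4 is therefore expected to be small, a 1.2-fold higher number from compound 1 to compound 4 (0.09 log units; within the scatter), with no direction firmly preferred. In this assay compound 4 is estimated at 60000 nM, within a range from 25000 nM to 150000 nM.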

Compound 4, minimum cytotoxic concentration: 200000 nM
The estimate for compound 4 lay 3.3-fold (0.52 log units) below the measured number; measured number above the stated range.
By their numbers in this assay, from the lowest: compound 1; then compounds 3 and 4 (each within the scatter of the next).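

In this assay, putting 2-chlorophenyl in place of benzyloxy on this saturated chain carbon gives a 4.1-fold higher number from compound 1 to compound 4 (0.61 log units; beyond the scatter) and so shows that the position is not indifferent to the group it carries. Among the compounds shown here, this is the first comparison here in which only one place differs, and it shows that the cells can tolerate more compound when the (benzyloxy)methyl arm gives way to 2-chlorobenzyl, an arm without the ether oxygen. Nothing measured here explains the size of this step.

For the compounds shown here, the single change removes the ether oxygen and brings in a chlorine at once, so the part each plays remains unresolved. An unsubstituted benzyl group, or a fluorine or methoxy group in place of the chlorine at this position, would help to separate the two.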